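The compounds below may be only part of what the source reports. "The series", "measured", "known", "first", "only" and "open" are said of these compounds alone.

Two compounds of one series have been characterised in a functional assay on NCI-H226 cells (Homo sapiens) for inhibition, read by sulforhodamine B assay, with a stated time of 48 h; a lower number here means a stronger inhibitor of growth, a higher number a weaker inhibitor of growth. Compound 1 `N=C(N)c1ccc(-c2ccc(-c3cc(Cl)cc(Cl)c3)s2)s1` carries a bis-thiophene core between an amidine and a dichlorophenyl group, and in this assay compound 1 gives 30800 nM. Compound 2 `COc1ccc(-c2ccc(-c3ccc(C(=N)N)o3)o2)cc1` replaces that core with a bis-furan core and bears a methoxyphenyl group, and in this assay compound 2 gives 22000 nM. Compound 2 thus has the smaller of the two numbers, but the gap to compound 1 lies within the scatter, so the two are treated as equal on the evidence at hand; neither is called stronger or weaker.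

Compound 3 `N=C(N)c1ccc(-c2ccc(-c3ccc(Cl)cc3)o2)o1` has not yet been measured. It keeps the whole of compound 2 except for one substituent: chloro in place of methoxy on an aromatic carbon. Among the compounds with values here, no measured pair in this set shows what such a swap does, so there is nothing to read a direction from. Compound 3 is therefore expected to give a step of about a 1.1-fold lower number from compound 2 to compound 3 (0.04 log units; within the scatter) in this assay, that is, no change beyond the scatter, and its value is estimated at 20000 nM, with a likely range from 7000 nM to 60000 nM.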

Compound 3, concentration for 50% growth inhibition: 2190 nM
Estimate against measurement, compound 3: 9.1-fold (0.96 log units) above; measured number below the stated range.
By their numbers in this assay, from the lowest: compound 3; then compounds 2 and 1 (each within the scatter of the next).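

In this assay, chloro in place of methoxy gives a 10-fold lower number from compound 2 to compound 3 (1.00 log units; beyond the scatter), so the group on this aromatic carbon, para to a large group, clearly matters to the read-out. The earlier compounds shown here could not show this: compounds 1 and 2 differ in more than one place and lie within the scatter of each other, whereas this single swap, with the rest of the structure held constant, gives a step beyond the scatter. It is still only one modest step, and no measurement shown here explains it.

The compounds shown leave open whether the step belongs to the arrival of chloro or to the departure of methoxy, a question that a fluoro group, a methyl group or a bare hydrogen at this position would help to answer. Also open, from the compounds shown here alone, is whether the same swap would give a similar step on the core of compound 1, and whether a step of this size would hold with an amine or a carboxylic acid in place of the amidine.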